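Replacing 4-hydroxy-2-methylphenyl with 4-ethylphenyl

A few compounds are considered here, and "the series" means these few. Any claim that something is new, unique, unknown or untested is made for them only; others in the source may bear on it.

Within the data shown here, in a functional assay on SF-268 cells (Homo sapiens) for inhibition, read by sulforhodamine B assay, with a stated time of 48 h (on this read-out lower numbers stand for stronger inhibition of growth and higher numbers for weaker inhibition of growth), compound 1 `Cc1ccc(C2=NN(c3ccc(S(C)(=O)=O)cc3)C(=O)CC2)cc1` gives 2940 nM and compound 2 `Cc1cc(O)ccc1C1=NN(c2ccc(S(C)(=O)=O)cc2)C(=O)CC1` gives 40000 nM as the highest of the two numbers so far. The change to compound 3 `CCc1ccc(C2=NN(c3ccc(S(C)(=O)=O)cc3)C(=O)CC2)cc1` is 4-ethylphenyl in place of 4-hydroxy-2-methylphenyl on a carbon with a double bond to nitrogen and puts 4-ethylphenyl in place of 4-hydroxy-2-methylphenyl on a carbon with a double bond to nitrogen. Among the measured compounds shown here, the one measured step that bears on it is a 14-fold higher number from compound 1 to compound 2 (1.13 log units; beyond the scatter) and it is large and beyond the scatter, with 4-hydroxy-2-methylphenyl in place of 4-methylphenyl on that same carbon. As far as these compounds go, compound 3 lacks 4-hydroxy-2-methylphenyl, as does compound 1 at 2940 nM so a large step to a lower number is expected in this assay while 4-ethylphenyl itself remains untested. The expected step is a 13-fold lower number from compound 2 to compound 3 (1.12 log units; beyond the scatter) and stands as an estimate only. The estimate for compound 3 is 3000 nM with an expected range from 1000 nM to 10000 nM in this series.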

Compound 3, concentration for 50% growth inhibition: 6990 nM
Estimate against measurement, compound 3: 2.3-fold (0.37 log units) below; low and high end bracket the measured number.
By their numbers in this assay, from the lowest: compound 1; then compound 3; then compound 2.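

With 4-ethylphenyl in place of 4-hydroxy-2-methylphenyl on the carbon with a double bond to nitrogen, this assay shows a 5.7-fold lower number from compound 2 to compound 3 (0.76 log units; beyond the scatter) and so a clear recovery at this position, though not a full one. Methyl in place of hydrogen on the saturated chain carbon bound to an aromatic carbon gives a 2.4-fold higher number from compound 1 to compound 3 (0.38 log units; beyond the scatter) and shows that even this small extension of the 4-methylphenyl group is not neutral here, which leaves compound 1 with the lowest number of the three. Nothing on hand explains either step.

The compounds shown do not separate the hydroxy from the added methyl within 4-hydroxy-2-methylphenyl. As far as these compounds go, how 4-methoxyphenyl, 4-aminophenyl or a longer chain such as 4-propylphenyl would read at this position remains open.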